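The source may hold more compounds than are shown below. What is called first, only, known or untested is meant among the compounds shown, and "the series" means these compounds.

Measured so far in a functional assay on RAW264.7 cells (Mus musculus) for inhibition, read by Griess assay, with stated times of 2 h and 24 h; on this read-out higher numbers stand for weaker inhibition and lower numbers for stronger inhibition:
- compound 1, `COc1ccc([C@@H]2CC(=O)c3c(O)cc(OCc4cn(Cc5ccccc5)nn4)cc3O2)cc1O`: 11000 nM
- compound 2, `COc1ccc([C@@H]2CC(=O)c3c(O)cc(OCc4cn(C)nn4)cc3O2)cc1O`: 15200 nM
- compound 3, `COc1ccc([C@@H]2CC(=O)c3c(O)cc(OCc4cn(Cc5ccc(C)cc5)nn4)cc3O2)cc1O`: 16800 nM

Compound 3 holds the highest number of the three, but its steps to the others are small: a 1.5-fold higher number from compound 1 to compound 3 (0.18 log units; within the scatter) and a 1.1-fold higher number from compound 2 to compound 3 (0.04 log units; within the scatter), both within the scatter. The three compounds therefore read as one level, and no order among them can be stated.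

Compound 4, `COc1ccc([C@@H]2CC(=O)c3c(O)cc(OCc4cn(CCCO)nn4)cc3O2)cc1O`, is the next step from compound 3. The change is 2-hydroxyethyl in place of 4-methylphenyl on a saturated chain carbon bound to an aromatic nitrogen. Among the measured steps, two touch the same place: a 1.4-fold higher number from compound 1 to compound 2 (0.14 log units; within the scatter) and a 1.1-fold higher number from compound 2 to compound 3 (0.04 log units; within the scatter). Both show that exchanging the group on the saturated chain carbon bound to the aromatic nitrogen, whether for hydrogen, phenyl or 4-methylphenyl, leaves the number in this assay where it was. Among the measured compounds shown here, none of the measured steps brings in a hydrogen-bond donor or acceptor at this place, so the effect of 2-hydroxyethyl is not covered by a direct precedent; what is available points to no step beyond the scatter.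

Compound 4 is therefore estimated at 15000 nM in this assay, with a range of 7000 nM to 32000 nM. The expected step is a 1.1-fold lower number from compound 3 to compound 4 (0.05 log units; within the scatter), no change beyond the scatter.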

Compound 4, half-maximal inhibitory concentration: 16700 nM
Beside the measured number, compound 4's estimate is 1.1-fold (0.05 log units) below it, and the stated range covers the measured number.
By their numbers in this assay, from the lowest: compounds 1, 2, 4 and 3 (each within the scatter of the next).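

In this assay, replacing the ring-bearing 4-methylbenzyl with 3-hydroxypropyl puts a hydrogen-bond donor and a hydrogen-bond acceptor at this place and removes the aromatic ring, yet the step stays within the scatter: a 1.0-fold lower number from compound 3 to compound 4 (0.00 log units; within the scatter). The same holds for the two other pairs, a 1.1-fold higher number from compound 2 to compound 4 (0.04 log units; within the scatter) and a 1.5-fold higher number from compound 1 to compound 4 (0.18 log units; within the scatter), so across these four compounds hydrogen, phenyl, 4-methylphenyl and 2-hydroxyethyl on a saturated chain carbon bound to an aromatic nitrogen all read as one level, with no compound going against this, and neither the ring nor the hydroxyl separates one compound from another in this read-out. No measurement at hand offers an explanation for this flat reading.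

On these data alone, whether an amine, a carboxylic acid or a longer chain at this place would give a step beyond the scatter remains open. As far as these compounds go, all four compounds also share the core of compound 1, so how far changes to that core would move the number in this assay remains open as well.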